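Furan-2-yl in place of cyclohexyl: expected size of step

The source may report more compounds than this note shows. Statements on the series, on what has been measured and on what is new or still open speak of the compounds shown alone.

In a functional assay on NCI-H460 cells (Homo sapiens) for cytotoxicity, read by MTT assay, with a stated time of 72 h (on this read-out higher numbers stand for weaker inhibition and lower numbers for stronger inhibition), compound 1 `CC(C)c1[nH]cnc1/C=c1\[nH]c(=O)/c(=C/c2cccc(Oc3ccc(F)cc3)c2)[nH]c1=O` gives 8.8 nM and compound 2 `O=c1[nH]/c(=C\c2ccccn2)c(=O)[nH]/c1=C\c1cccc(Oc2ccc(F)cc2)c1` gives 49.1 nM. Compound 3 `O=c1[nH]/c(=C\C2CCCCC2)c(=O)[nH]/c1=C\c1cccc(Oc2ccc(F)cc2)c1` gives > 1000 nM, which is a limit of the assay and not a number. Compound 4 `O=c1[nH]/c(=C\c2ccco2)c(=O)[nH]/c1=C\c1cccc(Oc2ccc(F)cc2)c1` differs from compound 3 by furan-2-yl in place of cyclohexyl on a double-bonded chain carbon bound to an aromatic carbon. Two large steps lead to the cyclohexyl group: an at least 110-fold higher number from compound 1 to compound 3 (2.05 log units; beyond the scatter) and an at least 20-fold higher number from compound 2 to compound 3 (1.30 log units; beyond the scatter). The two aromatic groups are separated by a modest step, a 5.6-fold higher number from compound 1 to compound 2 (0.75 log units; beyond the scatter). Compound 4 also carries an aromatic ring, so a large step towards stronger inhibition is expected, an at least 25-fold lower number from compound 3 to compound 4 (1.39 log units; beyond the scatter). For compound 4 the estimate is 40 nM, with an expected range from 12 nM to 200 nM.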

Compound 4, half-maximal inhibitory concentration: 155 nM
The estimate for compound 4 lay 3.9-fold (0.59 log units) below the measured number, within the range that was stated.
By their numbers in this assay, from the lowest: compound 1; then compound 2; then compound 4. At a limit, above all of these: compound 3.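

Furan-2-yl in place of cyclohexyl gives an at least 6.4-fold lower number from compound 3 to compound 4 (0.80 log units; beyond the scatter) on the double-bonded chain carbon, so a third aromatic ring also stands clear of the cyclohexyl compound. The aromatic groups themselves spread apart: a 3.2-fold higher number from compound 2 to compound 4 (0.50 log units; beyond the scatter) and an 18-fold higher number from compound 1 to compound 4 (1.25 log units; beyond the scatter) show that an aromatic ring alone does not set the level. Compound 3 stands at a limit and not at a number, so its step has only a bound: the limit of > 1000 nM in this assay, at which 1 of the 4 values shown sits.

Open, as far as these compounds go, is whether ring size or the ring hetero atom separates furan-2-yl from pyridin-2-yl. A phenyl or thiophen-2-yl group here, or the imidazole without its isopropyl group, would help to settle this.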